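Sulfonyl aryl change from compound 3 to compound 4

The source may report more compounds than this note shows. Statements on the series, on what has been measured and on what is new or still open speak of the compounds shown alone.

- compound 1 `N#C/C(=C\c1ccccc1OS(=O)(=O)c1ccc(F)cc1)C(=O)Nc1nnc(Cc2cccc3ccccc23)s1` gives 12%
- compound 2 `N#C/C(=C\c1ccccc1OS(=O)(=O)c1ccc(F)cc1)C(=O)Nc1nnc(Cc2ccccc2)s1` gives 22%
- compound 3 `N#C/C(=C\c1ccccc1OS(=O)(=O)c1ccccc1[N+](=O)[O-])C(=O)Nc1nnc(Cc2ccc(F)cc2)s1` gives 35%

In a functional assay on HL-60 cells (Homo sapiens) for inhibition, read by CCK-8 assay, with a stated time of 48 h, tested at 20 uM (on this read-out higher numbers stand for more inhibition of growth at the one concentration tested and lower numbers for less inhibition of growth), compound 3 stands highest of the three at 35% and lies beyond the scatter from both others. Compound 4 `N#C/C(=C\c1ccccc1OS(=O)(=O)c1ccc(F)cc1)C(=O)Nc1nnc(Cc2ccc(F)cc2)s1` differs from compound 3 by 4-fluorophenyl in place of 2-nitrophenyl on a sulfonyl sulfur. Compound 4 carries 4-fluorophenyl in place of 2-nitrophenyl on a sulfonyl sulfur. For the measured compounds named here, no measured step covers this change. Going by the values given here, the only step available is a number 10 percentage points higher from compound 1 to compound 2 (within the scatter) and concerns phenyl in place of naphthalen-1-yl elsewhere. Compound 1 at 12% and compound 2 at 22% both hold 4-fluorophenyl on the sulfonyl sulfur and sit lower than compound 3. A modest fall is therefore expected, namely a number 10 percentage points lower from compound 3 to compound 4 (within the scatter) and possibly no more than the scatter. Compound 4 is estimated at 25% in this assay with 13% to 38% as the expected range.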

Compound 4, percent growth inhibition at one concentration: 13%
The estimate for compound 4 lay 12 percentage points above the measured number, within the range that was stated.
By their numbers in this assay, from the lowest: compounds 1, 4 and 2 (each within the scatter of the next); then compound 3.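

In this assay, for the compounds shown here, the sulfonyl sulfur is the first position with a step beyond the scatter: 4-fluorophenyl in place of 2-nitrophenyl gives a number 22 percentage points lower from compound 3 to compound 4 (beyond the scatter) here. With 4-fluorophenyl held on the sulfonyl sulfur, fluoro in place of hydrogen gives a number 9 percentage points lower from compound 2 to compound 4 (within the scatter) and 4-fluorophenyl in place of naphthalen-1-yl gives a number 1 percentage points higher from compound 1 to compound 4 (within the scatter) on the chain side, both within the scatter. Nothing available accounts for the sulfonyl step.

Open, on these data alone, is whether an amine or a methoxy group on the sulfonyl phenyl would keep the number of compound 3. Also open, as far as these compounds go, is whether 2-nitrophenyl holds its step with phenyl or naphthalen-1-yl on the saturated chain carbon.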